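The source may hold more compounds than are shown below. What is called first, only, known or untested is meant among the compounds shown, and "the series" means these compounds.

Measured compounds:
Compound 1 `Cc1ccc2nc(C(=O)Nc3c(F)cc(-c4cccc(F)c4)cc3F)c(C)c(O)c2c1` — 16.2%
Compound 2 `CCc1ccc2nc(C(=O)Nc3c(F)cc(-c4cccc(F)c4)cc3F)c(C)c(O)c2c1` — 17.9%
Compound 3 `CCOc1ccc2nc(C(=O)Nc3c(F)cc(-c4cccc(F)c4)cc3F)c(C)c(C(=O)O)c2c1` — 35.2%

Of the compounds shown here, three have been measured in a functional assay on A-375 cells (Homo sapiens) for antiproliferative activity, read by MTT assay, with a stated time of 24 h, tested at 3.7 ug/mL; a lower number here means a weaker effect, a higher number a stronger effect of the compound at the concentration tested. Compound 1 gives 16.2% and compound 2 gives 17.9%; these two share a core and differ by hydrogen in place of methyl on a saturated chain carbon bound to an aromatic carbon, a change that made a step of a number 1.7 percentage points lower from compound 2 to compound 1 (within the scatter). Compound 3 gives 35.2%, the highest of the three numbers, and the difference between its core and the core of compound 2 is not broken down here.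

Compound 4 `COc1ccc2nc(C(=O)Nc3c(F)cc(-c4cccc(F)c4)cc3F)c(C)c(C(=O)O)c2c1` has not yet been measured in this assay. It differs from compound 3 by hydrogen in place of methyl on a saturated chain carbon bound to an oxygen on an aromatic ring. This is the same kind of change as that from compound 2 to compound 1, not the same one: there the carbon that loses its methyl is bound to an aromatic carbon, whereas here it is bound to an oxygen on an aromatic ring. Among the measured compounds shown here, only this one earlier example of the change is available, so the expectation rests on a single pair.

Because that earlier step, a number 1.7 percentage points lower from compound 2 to compound 1 (within the scatter), stayed within the scatter, compound 4 is expected to stand close to compound 3, with an estimated step of a number 2.2 percentage points lower from compound 3 to compound 4 (within the scatter). The estimate for compound 4 in this assay is 33%, with a likely range from 22% to 44%.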

Compound 4, a percentage reported as inhibition, at one concentration (the size of the read-out at that concentration, not a potency): 24.6%
Compound 4: middle estimate off by 8.4 percentage points, on the high side; the range from low to high includes it.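

In this assay, shortening ethoxy to methoxy on the core of compound 3 gives a step of a number 10.6 percentage points lower from compound 3 to compound 4 (beyond the scatter), so on this core the loss of one methyl is large enough to be read as a real, though modest, change. Set beside the shortening of ethyl to methyl on the other core, this step cannot be told apart from the earlier one, so the data give no sign that the change behaves differently from one core to the other: the same change on two cores in this assay, a number 1.7 percentage points lower (within the scatter) from compound 2 to compound 1 and a number 10.6 percentage points lower (beyond the scatter) from compound 3 to compound 4, 8.9 percentage points apart, within the scatter of two such steps This does not show that the change carries over with a fixed size, since it rests on only two pairs, one of which stays within the scatter, and those pairs differ both in their cores and in whether the carbon that loses its methyl is bound to an aromatic carbon or to an oxygen on an aromatic ring.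

The compounds shown leave open how a longer chain such as propoxy would read on the core of compound 3, and so whether the trend from methoxy to ethoxy continues. They also leave open whether the same shortening would give a similar step with an amine in place of the carboxylic acid of compound 3.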